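This account rests on a few compounds, and the source may have more. Where it says the series, first, only, none or still open, it means among the compounds named here.

Measured compounds:
- compound 1 `O=[N+]([O-])c1ccc(COc2ccc(OCCOCCNC3CCCC3)cc2)cc1`: 20300 nM
- compound 2 `c1ccc(COc2ccc(OCCOCCNC3CCOC3)cc2)cc1`: 48000 nM
- compound 3 `c1ccc(COc2ccc(OCCOCCNC3CCCCC3)cc2)cc1`: 7370 nM

In a functional assay on SK-OV-3 cells (Homo sapiens) for inhibition, read by CCK-8 assay, with a stated time of 70 h (a higher number here means a weaker inhibitor, a lower number a stronger inhibitor), compound 1 gives 20300 nM, the second highest of the three numbers: compound 2 sits higher and compound 3 lower, and both of those gaps lie beyond the scatter. For the measured compounds named here, the only measured step on this core is a 6.5-fold lower number from compound 2 to compound 3 (0.81 log units; beyond the scatter), a change at the amine nitrogen on the other end of the chain. Compound 4 `Nc1cccc(COc2ccc(OCCOCCNC3CCCC3)cc2)c1` is not yet measured. Compound 4 differs from compound 1 by 3-aminophenyl in place of 4-nitrophenyl on a saturated chain carbon bound to an oxygen on an aromatic ring. Going by the values given here, no measured step touches this part of the molecule, so the step from compound 2 to compound 3 gives no direct guidance and the direction of the change is open. With nothing in the data to point one way, the expectation for compound 4 in this assay is a number close to that of compound 1, with the change a 1.3-fold lower number from compound 1 to compound 4 (0.10 log units; within the scatter) expected to stay within or near the scatter. Compound 4 is therefore estimated at 16000 nM, with a range from 5000 nM to 50000 nM.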

Compound 4, half-maximal inhibitory concentration: 10800 nM
Compound 4: the middle estimate sits 1.5-fold (0.17 log units) above what was measured, within the range that was stated.
By their numbers in this assay, from the lowest: compounds 3, 4 and 1 (each within the scatter of the next, the first and the last beyond it); then compound 2.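

In this assay, the exchange on a saturated chain carbon bound to an oxygen on an aromatic ring gives a 1.9-fold lower number from compound 1 to compound 4 (0.27 log units; within the scatter) and so does not separate 3-aminophenyl from 4-nitrophenyl on the core of compound 1. For the compounds shown here, this is the first reading at this part of the molecule, and it shows that replacing a group of 9 heavy atoms, with 2 hydrogen-bond acceptors and no donor, by one of 7 heavy atoms, with 1 donor and 1 acceptor, leaves the reading within the scatter. Nothing measured alongside this result bears on it.

The amino and nitro groups appear at different places on the phenyl ring, so the kind of group and its place remain unseparated. From the compounds shown here alone, how a plain phenyl, or a phenyl carrying a nitrile or a carboxylic acid, would read on the core of compound 1 remains open.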